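The source may report more compounds than this note shows. Statements on the series, on what has been measured and on what is new or still open speak of the compounds shown alone.

Of the compounds shown here, three built on one shared core have been measured in a functional assay on HT-29 cells (Homo sapiens) for antiproliferative activity, read by MTT assay, with a stated time of 48 h (a higher number here means a weaker inhibitor, a lower number a stronger inhibitor), so far. There compound 1 `N#Cc1ncn(-c2ccc(F)cc2)c1/N=C/c1ccc([N+](=O)[O-])cc1` reads 15900 nM and compound 2 `COc1cc(/C=N/c2c(C#N)ncn2-c2ccc(F)cc2)ccc1O` reads 20100 nM as its half-maximal inhibitory concentration. Within the data shown here, compound 3 `N#Cc1ncn(-c2ccc(F)cc2)c1/N=C/c1ccc(O)cc1` comes in at 20400 nM and stands level with both, with no step to either lying beyond the scatter. Among the measured compounds shown here, the next structure is compound 4 `CC(C)c1ccc(/C=N/c2c(C#N)ncn2-c2ccc(F)cc2)cc1` with isopropyl in place of hydroxy on an aromatic carbon as its one change from compound 3.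

For the measured compounds named here, two measured steps bear on this change, since both touch a group on an aromatic carbon. Hydroxy in place of nitro gave a 1.3-fold higher number from compound 1 to compound 3 (0.11 log units; within the scatter) and hydrogen in place of methoxy gave a 1.0-fold higher number from compound 2 to compound 3 (0.01 log units; within the scatter) in the same measurement. Going by the values given here, no measured compound carries isopropyl, so this guidance is indirect. Neither step left the scatter, so no step beyond the scatter is expected in this assay and neither direction is clearly favoured. The expected change is a 1.3-fold lower number from compound 3 to compound 4 (0.11 log units; within the scatter) as a best estimate. For compound 4 the estimated value is 16000 nM within an expected range of 6000 nM to 40000 nM once measured.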

Compound 4, half-maximal inhibitory concentration: > 25000 nM
Compound 4: only a limit was reported; the forecaster's own chance of this, stated with the estimate: 10%; middle value at least 1.5-fold (0.19 log units) away from the limit.
By their numbers in this assay, from the lowest: compounds 1, 2 and 3 (each within the scatter of the next). At a limit, above all of these: compound 4.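

In this assay compound 4 is held only by a limit, not by a number: the limit of > 25000 nM in this assay, at which 1 of the 4 values shown sits. Isopropyl, which brings no hydrogen-bond donors or acceptors where hydroxy brought both, gives an at least 1.2-fold higher number from compound 3 to compound 4 (0.08 log units; that floor lies within the scatter), and set against nitro it gives an at least 1.5-fold higher number from compound 1 to compound 4 (0.19 log units; that floor lies within the scatter); both are floors that lie within the scatter, so the true size of either step cannot be read. Among these compounds, what this adds is that isopropyl is the first group at this position to give a limit rather than a readable number, and that it brought no stronger reading, although the result does not establish a real loss against hydroxy or nitro.

The compounds shown leave open whether an amine, a carboxylic acid or a longer chain at this position would give a number clearly apart from those of compounds 1, 2 and 3. They also leave open what number compound 4 itself would take, and so whether any change at this position moves the reading beyond the scatter.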